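Esters on the shared core and their half-lives

The source may report more compounds than this note shows. Statements on the series, on what has been measured and on what is new or still open speak of the compounds shown alone.

Compound 1 `CC(=O)Oc1ccccc1C(=O)O[C@H]1CO[C@H]2[C@@H]1OC[C@H]2O` carries a free hydroxy group on its saturated core. In an ADME assay on a cell-free system (plasma, Homo sapiens) for metabolic stability, with Plasma (Rattus norvegicus) as the target, read by HPLC, at pH 7.4 (a higher number here means that the compound lasts longer, a lower number that the compound disappears faster), compound 1 gives 0.0183 h. Among the three measured compounds, compound 1 holds the highest number, but its gaps to the other two are both within the scatter, so no order can be read from them. Compound 2 `CC(=O)Oc1ccccc1C(=O)O[C@H]1CO[C@H]2[C@@H]1OC[C@H]2OC(=O)c1cccc(O)c1` carries a (3-hydroxyphenyl)carbonyl on that oxygen, and in this assay compound 2 gives 0.015 h; the step of a 1.2-fold lower number from compound 1 to compound 2 (0.09 log units; within the scatter) stays within the scatter. Compound 3 `CCC(=O)O[C@@H]1CO[C@H]2[C@@H]1OC[C@@H]2OC(=O)c1ccccc1OC(C)=O` carries a propanoyl there instead, and in this assay compound 3 gives 0.011 h; again the step of a 1.7-fold lower number from compound 1 to compound 3 (0.22 log units; within the scatter) stays within the scatter, as does a 1.4-fold lower number from compound 2 to compound 3 (0.13 log units; within the scatter).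

Compound 4 `CC(=O)Oc1ccccc1C(=O)O[C@H]1CO[C@H]2[C@@H]1OC[C@H]2OC(=O)c1cccc(C)c1` differs from compound 1 in the same way: (3-methylphenyl)carbonyl in place of hydrogen on an oxygen on a saturated carbon. For the measured compounds named here, the steps that bear on it, a 1.2-fold lower number from compound 1 to compound 2 (0.09 log units; within the scatter) and a 1.7-fold lower number from compound 1 to compound 3 (0.22 log units; within the scatter), both replaced the hydrogen on that oxygen with an acyl group and both stayed within the scatter, with numbers drifting slightly lower. For compound 4 a step of a 1.2-fold lower number from compound 1 to compound 4 (0.09 log units; within the scatter) is therefore expected, most likely within the scatter and, if anything, towards a lower number. The half-life of compound 4 in this assay is estimated at 0.015 h, with a range from 0.008 h to 0.03 h.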

Compound 4, half-life: 0.0203 h
The estimate for compound 4 lay 1.4-fold (0.13 log units) below the measured number, within the range that was stated.
By their numbers in this assay, from the lowest: compounds 3, 2, 1 and 4 (each within the scatter of the next).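

Across the acyl groups at this position, the half-life shows no readable response in this assay: a 1.1-fold higher number from compound 1 to compound 4 (0.05 log units; within the scatter) with (3-methylphenyl)carbonyl in place of hydrogen on an oxygen on a saturated carbon, so the slight downward drift in the two earlier steps from compound 1 does not extend to a third acyl group. The steps among the acylated compounds tell the same story, with a 1.8-fold higher number from compound 3 to compound 4 (0.27 log units; within the scatter) for 3-methylphenyl in place of ethyl on a carbonyl carbon and a 1.4-fold higher number from compound 2 to compound 4 (0.13 log units; within the scatter) for methyl in place of hydroxy on an aromatic carbon, so neither swap can be told apart from repeat variation. Nothing available here bears on what sets these half-lives.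

The compounds shown leave open whether any group on this oxygen can move the half-life beyond the scatter, for instance an acyl group carrying an amine or a carboxylic acid, or an acyl chain longer than propanoyl. They also leave open whether an amide in place of the ester on the other side of the shared core would change the half-life.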